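The compounds below may be only part of what the source reports. "The series", "measured", "known", "first", "only" and "open" are said of these compounds alone.

Measured so far in an assay on Sf21 cells for inhibition of cytochrome c oxidase subunit 2 (Homo sapiens), read by spectrophotometry, with a stated time of 5 min; on this read-out higher numbers stand for weaker inhibition and lower numbers for stronger inhibition: compound 1 `NS(=O)(=O)c1ccc(N2C(=O)CC(C3CCCCC3=O)C2=O)cc1` gives 21300 nM; compound 2 `COc1ccc(C(=O)CC2CC(=O)N(c3ccc(S(N)(=O)=O)cc3)C2=O)cc1` gives 2100 nM; compound 3 `O=C1CCCCC1C1CC(=O)N(c2ccccc2)C1=O` gives 45100 nM.

Compound 3 stands at the highest of the three numbers, with compound 1 nearest to it. Within the data shown here, the one measured step, a 2.1-fold higher number from compound 1 to compound 3 (0.33 log units; beyond the scatter), concerns the aromatic carbon and says nothing about the ring nitrogen. Compound 4 `O=C1CCCCC1C1CC(=O)N(Cc2ccccc2)C1=O` differs from compound 3 by benzyl in place of phenyl on an amide-type nitrogen in a ring. Among the measured compounds shown here, no measured step bears on that place, so nothing speaks for a step beyond the scatter in either direction in this assay. For the measured compounds named here, for compound 4 the expectation is 45000 nM (range 15000 nM to 135000 nM), the step being estimated as a 1.0-fold lower number from compound 3 to compound 4 (0.00 log units; within the scatter), an expectation held with a wide range because no measured pair shows this change.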

Compound 4, half-maximal inhibitory concentration: 20000 nM
For compound 4 the middle estimate is 2.3-fold (0.35 log units) above the measured one; measured number inside the range.
By their numbers in this assay, from the lowest: compound 2; then compounds 4 and 1 (each within the scatter of the next); then compound 3.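

In this assay, among these compounds, benzyl in place of phenyl on the amide-type nitrogen gives a 2.3-fold lower number from compound 3 to compound 4 (0.35 log units; beyond the scatter) and so shows that this place, on which no earlier step bore, does respond to change. The two groups share one six-membered aromatic ring and have no hydrogen-bond donors or acceptors, yet the step lies beyond the scatter. No evidence at hand accounts for it.

Going by these compounds, whether a longer chain such as phenylethyl on this nitrogen moves the number further stays open. So does whether the step carries over to compounds bearing sulfamoyl on the aromatic ring.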